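Hexyl to benzyl sulfonamide on the bicyclic prostanoid acid core

This account rests on a few compounds, and the source may have more. Where it says the series, first, only, none or still open, it means among the compounds named here.

Compound 1 `CCCCCCS(=O)(=O)N[C@H]1C2CC[C@H](C2)[C@@H]1C/C=C\CCCC(=O)O` carries a hexyl sulfonamide on the shared core. Going by the values given here, in a functional assay (plasma) for inhibition, with Oryctolagus cuniculus as the target (a higher number here means a weaker inhibitor, a lower number a stronger inhibitor), compound 1 gives 13300 nM, the only single reported number in the set; the other measured member, compound 2 `O=C(O)CCC/C=C\C[C@H]1[C@@H]2CCC(C2)[C@@H]1NS(=O)(=O)c1ccccc1`, is recorded with several entries, and in this assay compound 2 gives 1000 nM; 7400 nM; 600 nM (3 entries), a spread that the several entries of compound 2 in this assay, 1000 nM; 7400 nM; 600 nM (3 entries) shows is wide even within the same compound. Among the compounds with values here, compound 2 differs from compound 1 in more than one place, so no step between them is drawn; the values simply stand side by side.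

The next member, compound 3 `O=C(O)CCC/C=C\C[C@H]1[C@@H]2CCC(C2)[C@@H]1NS(=O)(=O)Cc1ccccc1`, is reached from compound 1 by a single change: phenyl in place of pentyl on a saturated chain carbon bound to a sulfonyl sulfur. This puts an aromatic ring at the end of the sulfonamide, one bond further from the sulfur than the ring in compound 2 sits.

Within the data shown here, with no measured step of this kind to lean on, an improvement from compound 1 is expected, of roughly the size a 3.3-fold lower number from compound 1 to compound 3 (0.52 log units; beyond the scatter), beyond the usual scatter. For compound 3 in this assay the expected value is 4000 nM, with a plausible range from 1000 nM to 15000 nM.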

Compound 3, half-maximal inhibitory concentration: 113000 nM
The estimate for compound 3 lay 28-fold (1.45 log units) below the measured number; measured number outside the range, above it.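

In this assay, phenyl in place of pentyl on a saturated chain carbon bound to a sulfonyl sulfur gives an 8.5-fold higher number from compound 1 to compound 3 (0.93 log units; beyond the scatter), so in this pair the hexyl to benzyl change weakens inhibition rather than strengthening it. Going by these compounds alone, this is the only readable step so far, and it shows that the group on the sulfonamide can move the number on its own, with the shared core and the acid chain unchanged. The step is printed as beyond the usual scatter, but a single reading of compound 3 should be weighed against how far repeat entries for one compound can lie apart in this assay: the several entries of compound 2 in this assay, 1000 nM; 7400 nM; 600 nM (3 entries)

Within the data shown here, the two compounds in this step alone cannot separate the effect of the aromatic ring from that of losing the saturated chain, and no measured step yet links compound 2 to either of them. From the compounds shown here alone, how a shorter chain, a cyclohexyl group or a pyridine ring would read at this same place remains open, as does whether the weakening seen with benzyl extends to substituted benzyl groups.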